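A heteroaryl swap on a cell-growth read-out

The source may report more compounds than this note shows. Statements on the series, on what has been measured and on what is new or still open speak of the compounds shown alone.

Measured so far:
compound 1 `Cc1noc(C)c1-c1ccc2c(c1)C(c1ccccc1)N(Cc1ncc(-c3ccccc3)o1)C(=O)N2C` gives 3.7%
compound 2 `Cc1noc(C)c1-c1ccc2c(c1)C(c1ccccc1)N(Cc1nc(-c3ccc(F)cc3)cs1)C(=O)N2C` gives 8.5%

Both numbers come from an ADME assay on MCF-10A cells (Homo sapiens) for inhibition, read by MTT assay, with a stated time of 48 h, tested at 2 uM; a lower number here means less inhibition, a higher number more inhibition at the concentration tested (going by the name of the read-out). Within the data shown here, compound 1 holds the lower of the two numbers, but its only neighbour, compound 2, sits within the usual scatter of it, so no order between them can be claimed.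

Compound 3 `Cc1noc(C)c1-c1ccc2c(c1)C(c1ccccc1)N(Cc1csc(-c3ccc(F)cc3)n1)C(=O)N2C` is not yet measured. It differs from compound 1 in one place: 2-(4-fluorophenyl)-1,3-thiazol-4-yl in place of 5-phenyl-1,3-oxazol-2-yl on a saturated chain carbon bound to an amide-type nitrogen in a ring.

Among the measured compounds shown here, one measured step bears on this change. The replacement of the same group in compound 1 by a related fluorophenyl-bearing thiazolyl group gave a number 4.8 percentage points higher from compound 1 to compound 2 (within the scatter), a step that stays within the scatter. The change toward compound 3 is of the same kind, with the thiazole joined to the chain through a different ring carbon and the fluorophenyl group moved accordingly. For the measured compounds named here, with only one comparable step to draw on, and that step within the scatter, no movement beyond the scatter is expected: the step from compound 1 to compound 3 in this assay is estimated at a number 3.3 percentage points higher from compound 1 to compound 3 (within the scatter).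

Compound 3 is therefore expected to give about 7% in this assay, within a range from -3% to 18%.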

Compound 3, a percentage reported as inhibition, at one concentration (the size of the read-out at that concentration, not a potency): 6.8%
Beside the measured number, compound 3's estimate is 0.2 percentage points above it, and the stated range covers the measured number.
By their numbers in this assay, from the lowest: compounds 1, 3 and 2 (each within the scatter of the next).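

In this assay there is a number 3.1 percentage points higher from compound 1 to compound 3 (within the scatter), so a second fluorophenyl-bearing thiazolyl group on a saturated chain carbon bound to an amide-type nitrogen in a ring also gives no reading that can be told apart from that of the 5-phenyl-1,3-oxazol-2-yl group. The new comparison is between the two thiazolyl groups themselves: there is a number 1.7 percentage points lower from compound 2 to compound 3 (within the scatter), so changing from 4-(4-fluorophenyl)-1,3-thiazol-2-yl to 2-(4-fluorophenyl)-1,3-thiazol-4-yl, which alters the ring carbon joined to the chain, has no readable effect here either. No supporting measurement is available to explain these readings.

All three groups shown pair a five-membered aromatic ring with a six-membered aromatic ring of carbon only, so it remains open whether a group of a different kind at this place, such as an amine, a carboxylic acid or a longer chain, would move the reading beyond the scatter. The role of the fluorine also remains open, since the two thiazolyl groups both carry it and no otherwise matching group without it is shown.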